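The source may hold more compounds than are shown below. What is called first, only, known or untested is meant among the compounds shown, and "the series" means these compounds.

Compound 1, `COc1cccc(N2CCN(CC(=O)N3CCN(c4nnc(-c5ccccc5)c(-c5ccccc5)n4)CC3)CC2)c1`: in a functional assay on MCF7 cells (Homo sapiens) for cytotoxicity, read by MTT assay, with a stated time of 24 h (a lower number here means a stronger inhibitor, a higher number a weaker inhibitor), compound 1 reaches only the limit of the assay, > 910000 nM.
Compound 2, `Cc1ccc(-c2nnc(N3CCN(C(=O)CN4CCN(c5ccc(Cl)cc5)CC4)CC3)nc2-c2ccc(C)cc2)cc1`: in this assay compound 2 gives 660000 nM.
Compound 3, `COc1ccc(-c2nnc(N3CCN(C(=O)CN4CCN(c5ccccc5Cl)CC4)CC3)nc2-c2ccc(OC)cc2)cc1`: in this assay compound 3 reaches only the limit of the assay, > 814000 nM.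

Compound 3 therefore stands at the limit of > 814000 nM in this assay, at which 1 of the 3 values shown sits, a limit and not a number. Compound 1 likewise stands at the limit of > 910000 nM in this assay, at which 1 of the 3 values shown sits. Only compound 2 returns a number, and it too sits at the weak end of the range. Among the compounds with values here, no two of the measured compounds differ in a single place, so no measured step can be drawn among them.

Compound 4, `COc1ccc(-c2nnc(N3CCN(C(=O)CN4CCN(c5ccc(Cl)cc5)CC4)CC3)nc2-c2ccc(OC)cc2)cc1`, differs from compound 3 by 4-chlorophenyl in place of 2-chlorophenyl on an amine nitrogen in a ring. Within the data shown here, compound 2 also carries a 4-chlorophenyl on its ring nitrogen and gives a weak number rather than a limit, but it differs from compound 4 in other places as well, so it offers no measured step. The step from compound 3 to compound 4 in this assay is expected to be an at least 1.0-fold lower number from compound 3 to compound 4 (0.00 log units; that floor lies within the scatter), nothing beyond the scatter. Compound 4 is expected to give 800000 nM in this assay, somewhere between 400000 nM and 2000000 nM, and most likely to be reported only as a limit again.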

Compound 4, half-maximal inhibitory concentration: 607000 nM
Compound 4: middle estimate off by 1.3-fold (0.12 log units), on the high side; the range from low to high includes it.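

Within the data shown here, this is the first pair among the compounds that differs in one place, and it tests only where the chlorine sits on the phenyl group, with the atoms unchanged. In this assay, 4-chlorophenyl in place of 2-chlorophenyl on an amine nitrogen in a ring gives an at least 1.3-fold lower number from compound 3 to compound 4 (0.12 log units; that floor lies within the scatter), so the step has only a floor, and that floor shows no change beyond the scatter. The true size of the step stays unknown, because compound 3 is a limit and not a number: the limit of > 814000 nM in this assay, at which 1 of the 4 values shown sits.

The compounds shown leave open whether this step would hold on a different core, since the 4-chlorophenyl and 2-chlorophenyl pair is read on one core only. They also leave open whether a benzyl or pyridyl group, or a carboxylic acid, on this ring nitrogen would bring the values away from the weak end of this assay.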